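Fluorophenyl in Place of Pyridyl on a Cytotoxicity-Capped Series

The source may hold more compounds than are shown below. What is called first, only, known or untested is meant among the compounds shown, and "the series" means these compounds.

Compound 1, `Cc1nc2c(c(-c3cc(F)c4c(c3C)CCCO4)c1[C@H](OC(C)(C)C)C(=O)O)CN(CCCc1ccc(F)cc1)CC2`: > 40000 nM
Compound 2, `Cc1cccc(CCCN2CCc3nc(C)c([C@H](OC(C)(C)C)C(=O)O)c(-c4cc(F)c5c(c4C)CCCO5)c3C2)c1`: > 40000 nM
Compound 3, `Cc1nc2c(c(-c3cc(F)c4c(c3C)CCCO4)c1[C@H](OC(C)(C)C)C(=O)O)CN(CCCc1ccncc1)CC2`: > 40000 nM

The three measured compounds share one core and differ only in the aryl group on a saturated chain carbon, three bonds along the chain from an amine nitrogen in a ring. In an ADME assay on MT2 cells (Homo sapiens) for cytotoxicity, read by XTT assay, with a stated time of 4 days (a higher number here means that more compound is tolerated, a lower number that less compound is tolerated), compound 3 gives > 40000 nM, which is a limit of the assay and not a number. The same holds for compound 1 at > 40000 nM. Compound 2 likewise sits at > 40000 nM. The steps a step that the two limits leave unreadable from compound 1 to compound 2, a step that the two limits leave unreadable from compound 1 to compound 3 and a step that the two limits leave unreadable from compound 2 to compound 3 are therefore unreadable, since the limit of > 40000 nM in this assay, at which 3 of the 3 values shown sit, covers every value shown. Compound 4, `Cc1nc2c(c(-c3cc(F)c4c(c3C)CCCO4)c1[C@H](OC(C)(C)C)C(=O)O)CN(CCCc1ccccc1F)CC2`, differs from compound 3 by 2-fluorophenyl in place of pyridin-4-yl on a saturated chain carbon, three bonds along the chain from an amine nitrogen in a ring. With no readable step to draw on, compound 4 is expected to stay at the limit, with a step that the limit leaves unreadable from compound 3 to compound 4 as the expected step. The estimate for compound 4 is 45000 nM, ranging from 20000 nM to 100000 nM.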

Compound 4, half-maximal cytotoxic concentration: > 40000 nM
Compound 4: a limit, no number (the forecaster's own chance of this, stated with the estimate: 85%); the middle value lies beyond the limit too.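

Compound 4 gives a limit and not a number, as do compound 1, compound 2 and compound 3, so none of the steps among them can be read: the limit of > 40000 nM in this assay, at which 4 of the 4 values shown sit.

In this assay the compounds shown leave open whether these aryl groups differ at all.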